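This account rests on a few compounds, and the source may have more. Where it says the series, first, only, none or still open, it means among the compounds named here.

Compound 3 `Nc1scc(CN2CCN(CCCc3ccc(Cl)cc3)CC2)c1C(=O)c1ccc(Cl)cc1` gives -3% in a functional assay on CHO cells with adenosine receptor A1 (Homo sapiens) as the target, read by cAMP accumulation and immunoassay, with a stated time of 6 min, tested at 0.1 uM; a higher number here means a weaker effect of the compound at the concentration tested, a lower number a stronger effect. Among the three measured compounds it holds the second highest number; its nearest neighbour is compound 1 `CC(C)N1CCN(Cc2csc(N)c2C(=O)c2ccc(Cl)cc2)CC1`, which gives 3.6%, and the two lie within the scatter of each other, as do compound 3 and compound 2 `Nc1scc(CN2CCN(c3ccc(Cl)c(C(F)(F)F)c3)CC2)c1C(=O)c1ccc(Cl)cc1`, which gives -12%.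

Compound 4 `Nc1scc(CN2CCN(c3cccc(Cl)c3)CC2)c1C(=O)c1ccc(Cl)cc1` differs from compound 3 in one place: 3-chlorophenyl in place of 3-(4-chlorophenyl)propyl on an amine nitrogen in a ring. Among the measured compounds shown here, two measured steps bear on this. From compound 1 to compound 2, where an aromatic group was placed directly on the amine nitrogen in the ring in place of isopropyl, the change was a number 15.6 percentage points lower from compound 1 to compound 2 (beyond the scatter). From compound 2 to compound 3, the reverse kind of change, the shift was a number 9 percentage points higher from compound 2 to compound 3 (within the scatter). Taken together these point to a small move downward, or none beyond the scatter, when 3-chlorophenyl sits directly on that nitrogen. The account therefore expects a shift of a number 4 percentage points lower from compound 3 to compound 4 (within the scatter), and it estimates compound 4 at -7%, with a range from -20% to 6%.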

Compound 4, a percentage reported as activity, at one concentration (the size of the read-out at that concentration, not a potency): -20%
Beside the measured number, compound 4's estimate is 13 percentage points above it; measured number inside the range.
By their numbers in this assay, from the lowest: compounds 4, 2, 3 and 1 (each within the scatter of the next, the first and the last beyond it).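

In this assay, 3-chlorophenyl in place of 3-(4-chlorophenyl)propyl on the amine nitrogen in the ring gives a number 17 percentage points lower from compound 3 to compound 4 (beyond the scatter) and so separates these two groups at this position, which the within-scatter step between compound 2 and compound 3 did not do for a group set directly on that nitrogen. The same group in place of isopropyl gives a number 23.6 percentage points lower from compound 1 to compound 4 (beyond the scatter) while the exchange of one directly attached aryl group for the other gives a number 8 percentage points lower from compound 2 to compound 4 (within the scatter) so the two aryl-bearing compounds 2 and 4 cannot be told apart here. Nothing available on this result speaks to its cause.

Still open, as far as these compounds go, is how a benzyl or 2-phenylethyl group on that nitrogen would read, which would show how the number follows the length of the chain. Also open, from the compounds shown here alone, is whether a plain phenyl group, or a phenyl ring carrying a carboxylic acid or an amine in place of the chlorine, would stay with compound 2 and compound 4.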